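The compounds below may be only part of what the source reports. "The series", "measured", "known", "first", "only" and "open" are said of these compounds alone.

Working notes on the series. In a functional assay on PC-3 cells (Homo sapiens) for inhibition, read by MTT assay, with a stated time of 72 h (on this read-out higher numbers stand for weaker inhibition and lower numbers for stronger inhibition), compound 1 (`FC(F)(F)c1ccc(CSc2nc(N3CCNCC3)cc(C(F)(F)F)n2)cc1`), with hydrogen on the amine nitrogen in the ring, gives 15900 nM. With methyl on that nitrogen, compound 2 (`CN1CCN(c2cc(C(F)(F)F)nc(SCc3ccc(C(F)(F)F)cc3)n2)CC1`) gives 34700 nM. With ethyl there, compound 3 (`CCN1CCN(c2cc(C(F)(F)F)nc(SCc3ccc(C(F)(F)F)cc3)n2)CC1`) gives 27200 nM, a value within the scatter of both others.

The three measured steps all concern this nitrogen or the group on it: a 2.2-fold higher number from compound 1 to compound 2 (0.34 log units; beyond the scatter), a 1.7-fold higher number from compound 1 to compound 3 (0.23 log units; within the scatter) and a 1.3-fold lower number from compound 2 to compound 3 (0.11 log units; within the scatter). Only the first lies beyond the scatter, and it is modest.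

Compound 4 (`FC(F)(F)c1ccc(CSc2nc(N3CCN(c4ccccc4)CC3)cc(C(F)(F)F)n2)cc1`) has not been measured. It carries phenyl in place of ethyl on an amine nitrogen in a ring. For the measured compounds named here, the site is the same, but none of the measured steps brings a ring onto this nitrogen, so they serve only as a weak guide.

Going by the values given here, with the only step beyond the scatter being a 2.2-fold higher number from compound 1 to compound 2 (0.34 log units; beyond the scatter), no step beyond the scatter is expected in this assay, and no direction is favoured with confidence. The expected step is a 1.3-fold lower number from compound 3 to compound 4 (0.11 log units; within the scatter). For compound 4 the estimate is 21000 nM, with an expected range from 8000 nM to 50000 nM.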

Compound 4, half-maximal inhibitory concentration: 42700 nM
Compound 4: the middle estimate sits 2.0-fold (0.31 log units) below what was measured; the measured number falls inside the stated range.
By their numbers in this assay, from the lowest: compounds 1, 3, 2 and 4 (each within the scatter of the next, the first and the last beyond it).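

Phenyl brings the first ring onto this amine nitrogen, and in this assay it cannot be told apart from either alkyl group (a 1.6-fold higher number from compound 3 to compound 4 (0.20 log units; within the scatter); a 1.2-fold higher number from compound 2 to compound 4 (0.09 log units; within the scatter)). Only against hydrogen does it separate, in a step that is beyond the scatter but modest (a 2.7-fold higher number from compound 1 to compound 4 (0.43 log units; beyond the scatter)). This makes compound 4 the second compound, after compound 2, to stand apart from compound 1 in the direction of a higher number, while compound 3 goes against any such pattern because its step from compound 1 lies within the scatter (a 1.7-fold higher number from compound 1 to compound 3 (0.23 log units; within the scatter)), so no rule linking group size to the number can be drawn from these four compounds. Nothing at hand explains these numbers.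

On these data alone, whether a benzyl group, an acetyl group or a longer chain ending in a hydroxyl group on this nitrogen would give a step beyond the scatter from compound 1, in either direction, stays open. Also open, as far as these compounds go, is whether a chlorine or methoxy group on the new phenyl ring would shift the number from that of compound 4.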